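Swapping Chloro for Cyclopropyl: Clearance in Human Hepatocytes

This account rests on a few compounds, and the source may have more. Where it says the series, first, only, none or still open, it means among the compounds named here.

Measured so far:
compound 1, `COc1nc(C2=NOCC(c3ccc(Cl)cc3)N2)ccc1-n1cnc(C)c1`: 2 mL/min/kg
compound 2, `COc1nc(C2=NOCC(c3ccc(C4CC4)cc3)N2)ccc1-n1cnc(C)c1`: 208 mL/min/kg
compound 3, `COc1nc(C2=NOCC(c3cccc(Cl)c3)N2)ccc1-n1cnc(C)c1`: 15 mL/min/kg

The three measured compounds share one core and differ only in the aryl group on a saturated ring carbon. Compound 1 carries 4-chlorophenyl and compound 3 carries 3-chlorophenyl; the difference between the two cores is 3-chlorophenyl in place of 4-chlorophenyl on a saturated ring carbon. In an ADME assay on cells (Hepatocyte, Homo sapiens) for pharmacokinetics (on this read-out higher numbers stand for fast clearance and lower numbers for slow clearance), compound 1 gives 2 mL/min/kg and compound 3 gives 15 mL/min/kg, a step of a 7.5-fold higher number from compound 1 to compound 3 (0.88 log units; beyond the scatter).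

Compound 2 is compound 1 with cyclopropyl in place of chloro on an aromatic carbon. In this assay compound 2 gives 208 mL/min/kg, so the step is a 100-fold higher number from compound 1 to compound 2 (2.02 log units; beyond the scatter). Between the two remaining measured compounds the step is a 14-fold lower number from compound 2 to compound 3 (1.14 log units; beyond the scatter).

Compound 4, `COc1nc(C2=NOCC(c3cccc(C4CC4)c3)N2)ccc1-n1cnc(C)c1`, is not yet measured. It is compound 3 with cyclopropyl in place of chloro on an aromatic carbon. Within the data shown here, this is the same kind of change as the one from compound 1 to compound 2, but the place is not identical: in compound 2 the new group stands para to a large group, in compound 4 it stands meta to a large group. For compound 4 a large upward step of a 27-fold higher number from compound 3 to compound 4 (1.43 log units; beyond the scatter) is expected, because the same kind of change gave a 100-fold higher number from compound 1 to compound 2 (2.02 log units; beyond the scatter). Whether the different place around the change alters the size of that step cannot be told from a single earlier example. Compound 4 is thus estimated at 400 mL/min/kg, with a likely range from 80 mL/min/kg to 1500 mL/min/kg.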

Compound 4, clearance: 29 mL/min/kg
Beside the measured number, compound 4's estimate is 14-fold (1.14 log units) above it; measured number below the stated range.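

The change of chloro to cyclopropyl did not carry over at the same size from one core to the other: the same change on two cores in this assay, a 100-fold higher number (2.02 log units; beyond the scatter) from compound 1 to compound 2 and a 1.9-fold higher number (0.29 log units; within the scatter) from compound 3 to compound 4, 54-fold (1.73 log units) apart, beyond the scatter of two such steps.

On the core of compound 3, the change gives a 1.9-fold higher number from compound 3 to compound 4 (0.29 log units; within the scatter), so this assay does not tell these two compounds apart, and the large step seen with the 4-substituted phenyl does not reappear with the 3-substituted phenyl; the aryl group as a whole also matters, with 3-cyclopropylphenyl in place of 4-cyclopropylphenyl giving a 7.2-fold lower number from compound 2 to compound 4 (0.86 log units; beyond the scatter), and 3-cyclopropylphenyl in place of 4-chlorophenyl giving a 15-fold higher number from compound 1 to compound 4 (1.16 log units; beyond the scatter). Among these compounds, these results show that, in this series, the size of this step on one core is no safe guide to its size on another, but with only two examples they do not show which size is more typical or why the two differ.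

As far as these compounds go, it remains open how the step would behave on a further core, or at a third place on the phenyl ring. From the compounds shown here alone, it is also open whether a different group in the same places, such as fluoro, a nitrile or an amine, would show the same dependence on the core.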